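Swapping the sulfonyl aryl group: furan to methylpyridine

This account rests on a few compounds, and the source may have more. Where it says the series, first, only, none or still open, it means among the compounds named here.

The measured compounds, in a physicochemical assay for lipophilicity, read by HPLC, at pH 7.4; on this read-out lower numbers stand for lower lipophilicity and higher numbers for higher lipophilicity:
compound 1 `CNCc1cn(S(=O)(=O)c2ccco2)c(-c2cccnc2F)c1F` gives 0.2
compound 2 `CNCc1cn(S(=O)(=O)c2ccccn2)c(-c2cccnc2F)c1F` gives 0.44
compound 3 `CNCc1cn(S(=O)(=O)c2cccnc2C)c(-c2cccnc2F)c1F` gives 0.48

Compound 1 has the lowest of the three numbers in this assay, though its nearest neighbour compound 2 sits only a number 0.24 log units higher from compound 1 to compound 2 (within the scatter) and compound 3, the furthest, only a number 0.28 log units higher from compound 1 to compound 3 (within the scatter); all three values therefore lie within the usual scatter of one another, and no order among them can be claimed.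

Compound 4 `CNCc1cn(S(=O)(=O)c2cncc(C)c2)c(-c2cccnc2F)c1F` has not yet been measured in this assay. It differs from compound 1 in one place: 5-methylpyridin-3-yl in place of furan-2-yl on a sulfonyl sulfur. The two measured steps that bear on this change are the ones that also replace furan-2-yl on the sulfonyl sulfur with a six-membered aromatic ring holding one nitrogen: a number 0.24 log units higher from compound 1 to compound 2 (within the scatter) and a number 0.28 log units higher from compound 1 to compound 3 (within the scatter). Between the two pyridine-bearing compounds the gap is a number 0.04 log units higher from compound 2 to compound 3 (within the scatter). On this basis a small upward step is expected for compound 4, of a size such as a number 0.30 log units higher from compound 1 to compound 4 (within the scatter), still within the scatter. Compound 4 is thus estimated at 0.5 in this assay, within a range from 0.2 to 0.8.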

Compound 4, distribution coefficient: 0.61
For compound 4 the middle estimate is 0.11 log units below the measured one, within the range that was stated.
By their numbers in this assay, from the lowest: compounds 1, 2, 3 and 4 (each within the scatter of the next, the first and the last beyond it).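

In this assay, 5-methylpyridin-3-yl in place of furan-2-yl on the sulfonyl sulfur gives a number 0.41 log units higher from compound 1 to compound 4 (beyond the scatter), the first step from compound 1 in this set to lie beyond the scatter. That separation does not extend to the six-membered rings themselves: 5-methylpyridin-3-yl in place of 2-methylpyridin-3-yl gives a number 0.13 log units higher from compound 3 to compound 4 (within the scatter), and 5-methylpyridin-3-yl in place of pyridin-2-yl gives a number 0.17 log units higher from compound 2 to compound 4 (within the scatter), so no order can be claimed among compound 2, compound 3 and compound 4. Any claim that leaving furan-2-yl for a six-membered aromatic ring clears the scatter therefore holds only for compound 4, with compound 2 and compound 3 going against it, even though the hydrogen-bond donor and acceptor counts of the leaving and entering groups are the same.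

As far as these compounds go, whether a plain phenyl ring, or a pyridine ring carrying an amine or a carboxylic acid, on the sulfonyl sulfur would stay within the span of these four compounds remains open. No measurement offered here explains the step from furan-2-yl to 5-methylpyridin-3-yl.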